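The compounds below may be only part of what the source reports. "The series", "measured", "known", "first", "only" and "open" are said of these compounds alone.

Working notes on the series. Compound 2 `Cc1c(OCCCCOc2cccc(C(=O)O)c2)ccc(C(=O)CC2CCCC2)c1C` gives 22.4% in an assay on HEK293 cells for positive allosteric modulation of metabotropic glutamate receptor 2 (Rattus norvegicus), read by thallium flux, with a stated time of 2.5 min (on this read-out lower numbers stand for smaller maximal responses and higher numbers for larger maximal responses), the lowest of the two numbers seen; compound 1 `Cc1c(OCCCCOc2ccc(C(=O)O)c(Cl)c2)ccc(C(=O)CC2CCCC2)c1O` gives 80.8% in this assay, and compound 1 differs from compound 2 in more than one place. Compound 3 `Cc1c(OCCCCOc2ccc(C(=O)O)c(Cl)c2)ccc(C(=O)CC2CCCC2)c1C` is not yet measured. Its change from compound 2: 4-carboxy-3-chlorophenyl in place of 3-carboxyphenyl on an oxygen on a saturated carbon. Going by the values given here, no single-change step between measured compounds exists here, so compound 1 with its value 80.8% is the only pointer. For compound 3 a rise beyond the scatter is expected, a number 27.6 percentage points higher from compound 2 to compound 3 (beyond the scatter), giving an estimated 50%, between 20% and 85%.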

Compound 3, largest response reached (reported as percent of maximum), in percent of the reference or control that the assay uses: 61.8%
The estimate for compound 3 lay 11.8 percentage points below the measured number, and the stated range covers the measured number.
By their numbers in this assay, from the lowest: compound 2; then compound 3; then compound 1.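

With the aromatic methyl held constant, 4-carboxy-3-chlorophenyl in place of 3-carboxyphenyl on the oxygen gives a number 39.4 percentage points higher from compound 2 to compound 3 (beyond the scatter) in this assay, so this change alone moves the maximal response. With 4-carboxy-3-chlorophenyl held constant, methyl in place of hydroxy on an aromatic carbon gives a modest step, a number 19 percentage points lower from compound 1 to compound 3 (beyond the scatter), so the aromatic substituent also matters. No measurement here bears on the reason for either step.

The compounds shown do not separate the effect of the chlorine from that of the carboxylic acid's placement. From the compounds shown here alone, how a fluorine in place of the chlorine, or a longer chain between the two oxygens, would read remains open.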